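Extending an amine substituent on a chromanone-type compound

The compounds below may be only part of what the source reports. "The series", "measured", "known", "first", "only" and "open" are said of these compounds alone.

Measured compounds:
Compound 1 `COc1cc2c(cc1OC)C(=O)/C(=C/c1cccc(O)c1)CO2` gives 21.9% in an assay on isolated protein for inhibition of Amine oxidase [flavin-containing] A (Homo sapiens), read by fluorescence, with a stated time of 30 min, tested at 20 uM; a higher number here means more inhibition at the concentration tested (going by the name of the read-out), a lower number less inhibition.
Compound 2 `COc1cc2c(cc1OC)C(=O)/C(=C/c1ccc(CN(C)C)c(O)c1)CO2` gives 8.2% in this assay.

Compound 2 stands at the lower of the two numbers shown in this assay; its only neighbour is compound 1, which sits higher. Going by the values given here, the one measured step is a number 13.7 percentage points lower from compound 1 to compound 2 (beyond the scatter), a change that added a (dimethylamino)methyl group to an aromatic carbon and cost a modest but real amount of inhibition.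

Compound 3 `CCN(CC)Cc1ccc(/C=C2\COc3cc(OC)c(OC)cc3C2=O)cc1O` is not yet measured. Its difference from compound 2 is diethylamino in place of dimethylamino on a saturated chain carbon bound to an aromatic carbon. Among the compounds with values here, this is a small enlargement of a group already present, not the introduction of a new one, so the step from compound 1 to compound 2 does not speak directly to it; no measured step bears on swapping dimethylamino for diethylamino. With compound 2 already at a low number, there is little room to fall further, and no shown data point to a rise. The expectation for compound 3 is therefore a step of a number 0.8 percentage points higher from compound 2 to compound 3 (within the scatter), that is, no change beyond the scatter. Compound 3 is estimated at 9%, within a range from 0% to 20%.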

Compound 3, a percentage reported as inhibition, at one concentration (the size of the read-out at that concentration, not a potency): 9.5%
Estimate against measurement, compound 3: 0.5 percentage points below, and the stated range covers the measured number.
By their numbers in this assay, from the lowest: compounds 2 and 3 (each within the scatter of the next); then compound 1.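

In this assay, making the amine larger at this spot barely registers: swapping dimethylamino for diethylamino on the saturated chain carbon gives a number 1.3 percentage points higher from compound 2 to compound 3 (within the scatter) and so leaves the two compounds indistinguishable. The other comparison shows a number 12.4 percentage points lower from compound 1 to compound 3 (beyond the scatter) when (diethylamino)methyl replaces hydrogen on an aromatic carbon, so the loss of inhibition seen with the (dimethylamino)methyl group also appears with this second amine, and across these three compounds the presence of either amine group matters more than which of the two it is. Nothing available beyond these inhibition readings explains why either amine group lowers the number or why the two read alike.

The compounds shown leave open whether a ring amine such as piperidine or morpholine, or a primary amine, would behave like these two groups at the same place. They also do not tell whether a longer chain between the aromatic carbon and the nitrogen would change the reading.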